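The source may hold more compounds than are shown below. What is called first, only, known or untested is meant among the compounds shown, and "the series" means these compounds.

Measured so far in a toxicity assay on NIH3T3 cells (Mus musculus) for cytotoxicity, read by resazurin assay; a higher number here means that more compound is needed for the effect, a lower number that less compound is needed:
Compound 1 `COC(=O)c1ccc(NCc2cncn2Cc2cccc(Br)c2)cc1-c1ccccc1`: > 10000 nM
Compound 2 `Clc1ccc(NCc2cncn2Cc2ccc(-c3ccccc3)cc2)cc1-c1ccccc1`: > 1000 nM
Compound 3 `COc1ccc(NCc2cncn2Cc2ccc(-c3ccccc3)cc2N)cc1-c1ccccc1`: > 1000 nM

Compound 1 stands at > 10000 nM, which is a limit and not a number. That is the limit of > 10000 nM in this assay, at which 1 of the 3 values shown sits, and it belongs to compound 1 alone. The other two compounds sit at the limit of > 1000 nM in this assay, at which 2 of the 3 values shown sit, also a limit. None of the three therefore has a true half-maximal concentration yet.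

Compound 4 `COC(=O)c1ccc(NCc2cncn2Cc2ccc(N)cc2)cc1-c1ccccc1` has not been measured. It keeps the core of compound 1 but carries 4-aminophenyl in place of 3-bromophenyl on a saturated chain carbon bound to an aromatic nitrogen. Cut one bond further out, this reads 3-bromobenzyl to 4-aminobenzyl.

Among the compounds with values here, no two measured compounds differ in just one place, so the data do not show directly what such a swap does. The expectation rests on compound 1 and its limit of > 10000 nM: no step beyond the scatter is expected in this assay, and neither direction is favoured. The step expected is a number no higher from compound 1 to compound 4 (the limit leaves the size open). The assay may well report only a limit again. For compound 4 the expected value is 10000 nM, with an estimated range from 2000 nM to 30000 nM.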

Compound 4, half-maximal effective concentration: > 10000 nM
Compound 4: a limit, no number; the forecaster's own chance of this, stated with the estimate: 85%; the middle value sits exactly at the limit.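

Compound 1 and compound 4 both stand at a limit and not at a number, and no step between them can be read in this assay: the limit of > 10000 nM in this assay, at which 2 of the 4 values shown sit.

The compounds shown leave open what concentration, if any, gives the half-maximal effect for any of them, and so what replacing 3-bromophenyl with 4-aminophenyl does in this assay.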